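Changing the benzyl halogens on an orexin receptor antagonist

A few compounds are considered here, and "the series" means these few. Any claim that something is new, unique, unknown or untested is made for them only; others in the source may bear on it.

Compound 1 `COc1ccc(N2C(=O)N(Cc3c(F)cc(F)cc3F)c3ccccc3S2(=O)=O)cc1OC` was tested in an assay on HEK293 cells for displacement of a labelled ligand from Orexin receptor type 2 (Homo sapiens), read by scintillation counting, with a stated time of 90 min (on this read-out lower numbers stand for stronger inhibition and higher numbers for weaker inhibition), where compound 1 gives 2 nM. Among the three compounds measured so far it holds the second highest number: compound 2 `COc1cc(F)c(CN2C(=O)N(c3cc(OC)nc(OC)c3)S(=O)(=O)c3ccccc32)c(F)c1` gives 0.251 nM, and compound 3 `COc1cc(N2C(=O)N(Cc3c(F)cc(F)cc3F)c3ccccc3S2(=O)=O)ccn1` gives 63.1 nM. For the measured compounds named here, the only step between compounds differing in one place is a 32-fold higher number from compound 1 to compound 3 (1.50 log units; beyond the scatter).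

Compound 4 `COc1ccc(N2C(=O)N(Cc3c(F)cc(C)cc3Cl)c3ccccc3S2(=O)=O)cc1OC` has not yet been measured. It differs from compound 1 by 2-chloro-6-fluoro-4-methylphenyl in place of 2,4,6-trifluorophenyl on a saturated chain carbon bound to an amide-type nitrogen in a ring. Going by the values given here, no measured step touches the group on this saturated chain carbon; the step from compound 1 to compound 3 concerns the aryl group on the amide-type nitrogen, and compound 2 is not linked to compound 1 by a single change, so its value shows only that a lower number was reached. With the entering group, like the leaving one, being a single six-membered aromatic ring of carbon only, a small step, or none beyond the scatter, is expected. Compound 4 is estimated at 3 nM, within 0.8 nM to 12 nM, which is expected to mean a 1.5-fold higher number from compound 1 to compound 4 (0.18 log units; within the scatter).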

Compound 4, inhibition constant: 0.794 nM
The estimate for compound 4 lay 3.8-fold (0.58 log units) above the measured number; measured number outside the range, below it.
By their numbers in this assay, from the lowest: compound 2; then compound 4; then compound 1; then compound 3.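

In this assay, the group on the saturated chain carbon bound to the amide-type nitrogen in the ring proves able to shift the number: 2-chloro-6-fluoro-4-methylbenzyl in place of 2,4,6-trifluorobenzyl gives a 2.5-fold lower number from compound 1 to compound 4 (0.40 log units; beyond the scatter). For the compounds shown here, this is the first measured step at this place, and it shows that a swap keeping the same heavy-atom count and a single six-membered aromatic ring of carbon only can still move the result beyond the scatter, here towards stronger inhibition. Nothing available explains the shift.

Chlorine and methyl entered together, so these compounds do not show how much of the step belongs to each. Also open, going by these compounds, is what an amine or a nitrile would do in place of that methyl.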